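Compound 2 to compound 3: a change on one nitrogen

A few compounds are considered here, and "the series" means these few. Any claim that something is new, unique, unknown or untested is made for them only; others in the source may bear on it.

Values in a functional assay on Huh-7 cells (Homo sapiens) for cytotoxicity, read by sulforhodamine B assay, with a stated time of 72 h (on this read-out higher numbers stand for weaker inhibition and lower numbers for stronger inhibition), are as follows
- compound 1 `Cc1ccc(-c2cc(C(=O)Nc3ccnc(Cl)c3)nn2-c2ccc3ccccc3n2)cc1` gives 1600 nM
- compound 2 `Cc1ccc(-c2cc(C(=O)NCc3cccnc3)nn2-c2ccc3ccccc3n2)cc1` gives 14100 nM
- compound 3 `Cc1ccc(-c2cc(C(=O)Nc3ccncc3Br)nn2-c2ccc3ccccc3n2)cc1` has not yet been measured

Of the two numbers available, compound 2 has the higher (14100 nM), which means the weaker inhibition. Among the compounds with values here, its only neighbour is compound 1 (1600 nM). Compound 3 differs from compound 2 at a single place, on an amide-type nitrogen whose other neighbour is the carbonyl carbon (3-bromopyridin-4-yl in place of (pyridin-3-yl)methyl on an amide-type nitrogen). Just one measured step bears on this change. It is an 8.8-fold higher number from compound 1 to compound 2 (0.95 log units; beyond the scatter) and is modest but beyond the scatter, with (pyridin-3-yl)methyl taking the place of 2-chloropyridin-4-yl at the same nitrogen. The change to compound 3 runs the other way, removing (pyridin-3-yl)methyl, but it brings in 3-bromopyridin-4-yl rather than 2-chloropyridin-4-yl, and no measurement compares those two groups directly. A step of broadly similar size, though less certain, is therefore expected toward lower numbers. The step expected in this assay is a 6.4-fold lower number from compound 2 to compound 3 (0.81 log units; beyond the scatter) toward stronger inhibition. The value expected for compound 3 is estimated at 2200 nM (700 nM to 7000 nM).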

Compound 3, half-maximal inhibitory concentration: 13100 nM
Compound 3: middle estimate off by 6.0-fold (0.77 log units), on the low side; measured number outside the range, above it.
By their numbers in this assay, from the lowest: compound 1; then compounds 3 and 2 (each within the scatter of the next).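

In this assay, the step of a 1.1-fold lower number from compound 2 to compound 3 (0.03 log units; within the scatter) shows that exchanging (pyridin-3-yl)methyl for 3-bromopyridin-4-yl on this amide-type nitrogen makes no difference beyond the scatter, so the earlier step from compound 1 to compound 2 cannot be read as a general effect of removing (pyridin-3-yl)methyl. The step of an 8.2-fold higher number from compound 1 to compound 3 (0.91 log units; beyond the scatter) separates two halogenated pyridine groups at the same place, showing that 3-bromopyridin-4-yl does not reproduce what 2-chloropyridin-4-yl gives, and that compound 1 alone stands apart from the other two compounds, beyond the scatter. No supporting evidence is available to explain why these two groups differ.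

The three compounds leave open whether the halogen itself or where it sits on the pyridine ring accounts for the gap, a question that 3-chloropyridin-4-yl and 2-bromopyridin-4-yl on the same nitrogen would address. They also leave open what plain pyridin-4-yl would give here, and so whether 2-chloropyridin-4-yl lowers the number or 3-bromopyridin-4-yl raises it.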